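Swapping Fluoro for Chloro on the Benzyl Ring

This account rests on a few compounds, and the source may have more. Where it says the series, first, only, none or still open, it means among the compounds named here.

Compound 2 `COc1cccc(Cn2[nH]c(C(F)(F)F)c(Cc3ccc(F)cc3)c2=O)c1` carries a fluoro group on an aromatic carbon of the benzyl ring that its parent, compound 1 `COc1cccc(Cn2[nH]c(C(F)(F)F)c(Cc3ccccc3)c2=O)c1`, lacks. In an assay for binding affinity to Endothelin-1 receptor (Rattus norvegicus) (on this read-out lower numbers stand for stronger inhibition and higher numbers for weaker inhibition), compound 1 gives 98000 nM, while compound 2 gives 40000 nM. Among the compounds with values here, that single exchange, a 2.5-fold lower number from compound 1 to compound 2 (0.39 log units; beyond the scatter), leaves compound 2 with the lowest number of the two measured so far, and compound 1 is its only neighbour. Compound 3 `COc1cccc(Cn2[nH]c(C(F)(F)F)c(Cc3ccc(Cl)cc3)c2=O)c1` has not yet been measured. It differs from compound 2 in one place: chloro in place of fluoro on an aromatic carbon. Within the data shown here, only one measured step bears on this change, the hydrogen-to-fluoro exchange on the same aromatic carbon, and it was modest in size. Among the measured compounds shown here, no measured pair here shows a fluoro-to-chloro exchange directly. On that footing one expects a small further decrease at most, or none beyond the scatter, and estimates the step of a 1.8-fold lower number from compound 2 to compound 3 (0.26 log units; within the scatter). In this assay compound 3 is therefore expected to give about 22000 nM, within a range from 8000 nM to 60000 nM.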

Compound 3, half-maximal inhibitory concentration: 4300 nM
Compound 3: middle estimate off by 5.1-fold (0.71 log units), on the high side; measured number outside the range, below it.
By their numbers in this assay, from the lowest: compound 3; then compound 2; then compound 1.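

With this result the identity of the group on this aromatic carbon, para to a large group, proves to matter as well as its presence: in this assay, chloro in place of fluoro gives a 9.3-fold lower number from compound 2 to compound 3 (0.97 log units; beyond the scatter) on an otherwise unchanged structure. Measured against the unsubstituted benzyl compound, chloro gives a 23-fold lower number from compound 1 to compound 3 (1.36 log units; beyond the scatter) and is rated a large step, whereas the fluoro exchange alone gave a 2.5-fold lower number from compound 1 to compound 2 (0.39 log units; beyond the scatter) and was only modest, so the earlier pair had shown only a small part of what this position can do. Nothing at hand accounts for the difference between the two halogens at this place and the three compounds give order without explanation.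

The compounds shown leave open whether the order hydrogen, fluoro, chloro continues with a bromo group or a methyl group on the same carbon, or whether it breaks with an amine or a carboxylic acid there. They also leave open whether chloro would give a similar step on another carbon of the 4-chlorobenzyl ring or alongside a different group in place of the trifluoromethyl of the shared core.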